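This account rests on a few compounds, and the source may have more. Where it says the series, first, only, none or still open, it means among the compounds named here.

Measured compounds:
compound 1 `O=C(Nc1ncc(F)s1)[C@H](CC1CCCC1)n1cc(S(=O)(=O)C2CC2)cn1` with 0.85 in an ADME assay on microsomes from liver (Rattus norvegicus); a higher number here means that the liver removes a larger share of the compound in one pass, a lower number that the liver removes a smaller share;
compound 2 `O=C(Nc1ncc(Cl)s1)[C@H](CC1CCCC1)n1cc(S(=O)(=O)C2CC2)cn1` with 0.85 in this assay.

In this assay compound 1 gives 0.85, and compound 2 gives 0.85. Compound 1 stands level with compound 2 at the digits shown; the single measured step, no change at the digits printed from compound 1 to compound 2 (within the scatter), lies within the scatter, and the only difference between these two is a chloro in place of a fluoro on an aromatic carbon.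

Compound 3 `O=C(Nc1ncc(F)s1)[C@H](CC1CCOCC1)n1cc(S(=O)(=O)C2CC2)cn1` has not yet been measured in this assay. It differs from compound 1 as follows: oxan-4-yl in place of cyclopentyl on a saturated chain carbon, two bonds along the chain from an aromatic nitrogen and a carbonyl carbon. Within the data shown here, the halogen swap measured so far does not touch this part of the molecule, so no measured step bears directly on the change from compound 1 to compound 3, and the expectation rests on compound 1 alone. Since both measured compounds sit at the same high reading, the estimate for compound 3 is placed close to compound 1, with a range widened to allow for a change in either direction; the expected step is a number 0.070 lower from compound 1 to compound 3 (within the scatter). Compound 3 is therefore estimated at 0.78, expected between 0.55 and 0.92.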

Compound 3, hepatic extraction ratio: 0.31
Beside the measured number, compound 3's estimate is 0.47 above it, and the stated range ends above it.
By their numbers in this assay, from the lowest: compound 3; then compounds 1 and 2 (each within the scatter of the next).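

Oxan-4-yl in place of cyclopentyl on a saturated chain carbon, two bonds along the chain from an aromatic nitrogen and a carbonyl carbon, shifts the reading in this assay well beyond the scatter, with a number 0.54 lower from compound 1 to compound 3 (beyond the scatter). The only earlier step, the halogen swap, gave no change at the digits printed from compound 1 to compound 2 (within the scatter), so this position is the first place among the compounds shown where the read-out responds to a change in structure. The change replaces a five-membered ring of carbon only with a six-membered ring holding 1 oxygen and 1 hydrogen-bond acceptor, and nothing measured here bears on why the reading drops so far.

The single step changes ring size and ring oxygen together, so the compounds shown leave open which of the two carries the drop; a cyclohexyl group at this place would separate them. They also leave open whether chloro in place of fluoro on an aromatic carbon would still give no change once oxan-4-yl is present, as it did with cyclopentyl.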